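Swapping tert-butyl for trifluoromethoxy on a weak sulfonamide

The compounds below may be only part of what the source reports. "The series", "measured", "known", "first", "only" and "open" are said of these compounds alone.

Measured compounds:
compound 1 `CC1CCN(C2CCN(S(=O)(=O)c3ccc(C(C)(C)C)cc3)CC2)CC1`, > 5000 nM
compound 2 `COc1ccc(-c2cccc(S(=O)(=O)N3CCC(N4CCC(C)CC4)CC3)c2)cc1`, 23 nM

In a functional assay on DLD-1 cells (Homo sapiens) for antiproliferative activity, read by CellTiter-Glo, with a stated time of 72 h (a higher number here means a weaker inhibitor, a lower number a stronger inhibitor), compound 1 returns only a limit, > 5000 nM, so no number is known for it. Compound 2 gives 23 nM in this assay, but the two compounds differ in more than one place, so nothing beyond the two values themselves can be read from the pair. The record for compound 1 is therefore the line (the limit of > 5000 nM in this assay, at which 1 of the 2 values shown sits).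

Compound 3 `CC1CCN(C2CCN(S(=O)(=O)c3ccc(OC(F)(F)F)cc3)CC2)CC1` is made from compound 1 by a single change: trifluoromethoxy in place of tert-butyl on an aromatic carbon. Going by the values given here, with no step between two measured compounds to lean on, the size of the move from compound 1 is expected to be small in this assay, a shift in either direction not beyond the scatter. For compound 3 the estimated outcome is 6000 nM, within 1500 nM to 25000 nM. This expectation corresponds to a step that the limit leaves unreadable from compound 1 to compound 3.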

Compound 3, half-maximal inhibitory concentration: 16 nM
Estimate against measurement, compound 3: 380-fold (2.57 log units) above; measured number below the stated range.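

In this assay, exchanging tert-butyl for trifluoromethoxy on an aromatic carbon, para to a large group, gives an at least 310-fold lower number from compound 1 to compound 3 (2.49 log units; beyond the scatter). This shows that, on the core of compound 1, the group at this position can decide whether a measurable potency appears at all, which the earlier pair could not show because its members differ in more than one place. The value of compound 1, > 5000 nM, is a limit and not a number, so the true size of the step stays unknown: the limit of > 5000 nM in this assay, at which 1 of the 3 values shown sits.

What the compounds shown leave open is which part of trifluoromethoxy carries the effect, the oxygen or the fluorines. From the compounds shown here alone, whether a methoxy, a trifluoromethyl or a chlorine at the same carbon would behave like trifluoromethoxy or like tert-butyl also remains open.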